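The source may hold more compounds than are shown below. What is called first, only, known or untested is meant among the compounds shown, and "the series" means these compounds.

Measured so far in a functional assay on HEK293 cells for negative allosteric modulation of metabotropic glutamate receptor 5 (Homo sapiens), read by calcium flux, with a stated time of 20 min; on this read-out higher numbers stand for weaker inhibition and lower numbers for stronger inhibition:
compound 1 `O=C(c1ccccc1)N1CCn2nc(-c3cccnc3)cc2C1` gives > 10000 nM, a limit of this assay and not a number.
compound 2 `O=C(c1ccc(Cl)cc1)N1CCn2nc(-c3ccccn3)cc2C1` gives 9470 nM.

For compound 1 only the limit is known, so its standing in this assay rests on the limit of > 10000 nM in this assay, at which 1 of the 2 values shown sits, alone. For the measured compounds named here, no step between measured compounds is available. Compound 3 `O=C(c1ccccc1)N1CCn2nc(-c3ccc(Cl)cn3)cc2C1` carries 5-chloropyridin-2-yl in place of pyridin-3-yl on an aromatic carbon, in words 5-chloropyridin-2-yl in place of pyridin-3-yl on an aromatic carbon. Going by the values given here, no measured step shows the direction of this change; a gain beyond the scatter is expected. The step is estimated as an at least 3.3-fold lower number from compound 1 to compound 3 (0.52 log units; beyond the scatter). Compound 3 is expected at 3000 nM, within 500 nM to 12000 nM.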

Compound 3, half-maximal inhibitory concentration: 201 nM
Compound 3: middle estimate off by 15-fold (1.17 log units), on the high side; the whole stated range lies above it.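

For the compounds shown here, this position on the five-membered aromatic ring responds strongly to the group it carries: in this assay, 5-chloropyridin-2-yl in place of pyridin-3-yl gives an at least 49-fold lower number from compound 1 to compound 3 (1.69 log units; beyond the scatter), the first readable step. The change joins a new attachment point on the pyridine with a chlorine, and this step does not separate the two. Compound 1 carries only a limit, so the size of the step is a bound: the limit of > 10000 nM in this assay, at which 1 of the 3 values shown sits.

Open, from the compounds shown here alone, is how far pyridin-2-yl without chlorine would carry the gain. Also open, going by these compounds, is how 5-methylpyridin-2-yl or 5-aminopyridin-2-yl would read at this place.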